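The source may report more compounds than this note shows. Statements on the series, on what has been measured and on what is new or still open speak of the compounds shown alone.

Compound 1, `C#Cc1cn([C@@H]2O[C@H](CO)[C@@H](O)[C@@H]2O)c(=O)[nH]c1=O`: 168000 nM
Compound 2, `CC1(C)[C@@H](CCCO)C[C@H]1n1nnc2c(N)nc(N)nc21`: > 200000 nM

Of the compounds shown here, two have been tested in an ADME assay on L1210/0 cells (Mus musculus) for cytotoxicity, with a stated time of 48 h; a lower number here means a stronger inhibitor, a higher number a weaker inhibitor. For the measured compounds named here, compound 1 gives 168000 nM there and is the only compound with an actual number. Compound 2 is reported only as a limit of the assay, > 200000 nM, not as a measured number. So compound 1 stands as the single numerical point, while the other entry, (the limit of > 200000 nM in this assay, at which 1 of the 2 values shown sits), is a limit and nothing more. Going by the values given here, no pair of measured compounds differs in a single place, so no measured step exists to set expectations.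

Compound 3, `CCC#Cc1cn([C@@H]2O[C@H](CO)[C@@H](O)[C@@H]2O)c(=O)[nH]c1=O`, is not yet measured. It differs from compound 1 in one place: ethyl in place of hydrogen on a triple-bonded carbon. Among the compounds with values here, with no measured step of this kind, the expectation rests on compound 1 alone. The change is expected to weaken the effect somewhat, a step of a 1.5-fold higher number from compound 1 to compound 3 (0.17 log units; within the scatter) in this assay, though it could stay within the usual scatter. Compound 3 is therefore estimated at 250000 nM, with a range from 80000 nM to 800000 nM, and a real chance that the assay reports only a limit.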

Compound 3, half-maximal inhibitory concentration: > 200000 nM
Compound 3 was reported as a limit; the forecaster's own chance of this, stated with the estimate: 55%; the middle value is on the limit's open side.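

In this assay, ethyl in place of hydrogen on a triple-bonded carbon gives an at least 1.1-fold higher number from compound 1 to compound 3 (0.07 log units; that floor lies within the scatter). That figure is only a floor, set by a limit rather than a measured number, so the true size of the step could lie within the scatter or far beyond it. What the result adds is a first direct reading at this position: going from ethynyl to but-1-yn-1-yl brings no gain in strength in this assay, and the one compound with a real number remains compound 1, while the readings now gather at a single ceiling: the limit of > 200000 nM in this assay, at which 2 of the 3 values shown sit.

On these data alone, how much weaker compound 3 really is stays open, and so does whether the weak effect in this cell assay depends on the ethyl group itself or would hold for any addition at this carbon. The compounds shown also leave open what a longer chain, a phenyl ring or an amine on the triple-bonded carbon would do, and whether any of these would bring the number below that of compound 1.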